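This account rests on a few compounds, and the source may have more. Where it says the series, first, only, none or still open, it means among the compounds named here.

Compound 1 `O=C(NCc1cccs1)N1C(=O)c2ccccc2S1(=O)=O` is the starting point. In a physicochemical assay for pharmacokinetics (a lower number here means that the compound disappears faster, a higher number that the compound lasts longer), compound 1 gives > 166 h, which is a limit rather than a measured number. Compound 2 `O=C(CCc1ccccc1)N1C(=O)c2ccccc2S1(=O)=O` gives > 166 h in this assay, also a limit. Among the compounds with values here, both known values therefore rest at the limit of > 166 h in this assay, at which 2 of the 2 values shown sit, so no measured step between them can be sized. Compound 3 `Cc1ccccc1CNC(=O)N1C(=O)c2ccccc2S1(=O)=O` differs from compound 1 by 2-methylphenyl in place of thiophen-2-yl on a saturated chain carbon bound to an amide-type nitrogen. With nothing measured beyond the limit, no change beyond the usual scatter is expected for the step that the limit leaves unreadable from compound 1 to compound 3. Compound 3 is expected to give about 200 h, between 90 h and 450 h, most likely reported again only as a limit.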

Compound 3, half-life: > 166 h
Compound 3 gave a limit, no number; the forecaster's own chance of this, stated with the estimate: 85%; the middle value does not contradict the limit.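

Compound 3 and compound 1 both stop at a limit, so the step between them cannot be read: the limit of > 166 h in this assay, at which 3 of the 3 values shown sit.

The compounds shown leave open how long any of them actually lasts in this assay, and whether 2-methylphenyl and thiophen-2-yl differ there at all.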